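A few compounds are considered here, and "the series" means these few. Any claim that something is new, unique, unknown or untested is made for them only; others in the source may bear on it.

Compound 1 `COc1ccc([C@@H]2CC(=O)c3c(O)cc(OCc4cn(Cc5ccccc5C(F)(F)F)nn4)cc3O2)cc1O` and compound 2 `COc1ccc([C@@H]2CC(=O)c3c(O)cc(OCc4cn(Cc5ccccc5C#N)nn4)cc3O2)cc1O` share one core and differ in a single group on an aromatic carbon. In a functional assay on RAW264.7 cells (Mus musculus) for inhibition, read by Griess assay, with stated times of 2 h and 24 h (a higher number here means a weaker inhibitor, a lower number a stronger inhibitor), compound 1 gives 12500 nM, and compound 2 gives 14600 nM. On the two numbers shown compound 2 stands at the top, yet the step of a 1.2-fold higher number from compound 1 to compound 2 (0.07 log units; within the scatter) lies within the scatter, so the two compounds cannot be ranked against each other. Compound 3 `COc1ccc([C@@H]2CC(=O)c3c(O)cc(OCc4cn(Cc5ccccc5Cl)nn4)cc3O2)cc1O` differs from compound 2 by chloro in place of cyano on an aromatic carbon. For the measured compounds named here, the only measured step that bears on this change is the one already named, a 1.2-fold higher number from compound 1 to compound 2 (0.07 log units; within the scatter), which exchanged one small group for another at the same place and did not move the number. Nothing measured therefore points to a step beyond the scatter in this assay in either direction. Compound 3 is accordingly expected to give about 13000 nM in this assay, within a range from 6000 nM to 28000 nM. This expectation amounts to a step of a 1.1-fold lower number from compound 2 to compound 3 (0.05 log units; within the scatter).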

Compound 3, half-maximal inhibitory concentration: 6140 nM
The estimate for compound 3 lay 2.1-fold (0.33 log units) above the measured number, and the stated range covers the measured number.
By their numbers in this assay, from the lowest: compound 3; then compounds 1 and 2 (each within the scatter of the next).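

In this assay, the group on this aromatic carbon, ortho to a large group, proves able to shift the number: chloro in place of cyano gives a 2.4-fold lower number from compound 2 to compound 3 (0.38 log units; beyond the scatter), and chloro in place of trifluoromethyl gives a 2.0-fold lower number from compound 1 to compound 3 (0.31 log units; beyond the scatter). The earlier exchange, a 1.2-fold higher number from compound 1 to compound 2 (0.07 log units; within the scatter), had not separated cyano from trifluoromethyl, so among the compounds shown, chloro alone stands apart, though both of its steps are modest. Nothing available explains why chloro stands apart from the other two groups.

The compounds shown carry only chloro, cyano and trifluoromethyl at this place, so how an amine, a carboxylic acid or a bromo group would read there remains open. Also open, from the compounds shown here alone, is whether chloro would give a similar step on another carbon of the same ring.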